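Methoxy in place of amino on compound 3

A few compounds are considered here, and "the series" means these few. Any claim that something is new, unique, unknown or untested is made for them only; others in the source may bear on it.

In a functional assay on MCF7 cells (Homo sapiens) for inhibition, read by MTT assay, with a stated time of 2 days (on this read-out lower numbers stand for stronger inhibition and higher numbers for weaker inhibition), compound 1 (`Nc1cccc(/C=C/c2ccccc2)c1`) gives 14 ug/mL, compound 2 (`Oc1ccc(/C=C/c2cccc(O)c2)cc1`) gives 23 ug/mL and compound 3 (`Nc1cccc(/C=C/c2ccc(O)cc2)c1`) gives 6 ug/mL, the lowest of the three numbers. Compound 4 (`COc1cccc(/C=C/c2ccc(O)cc2)c1`) awaits measurement and has methoxy in place of amino on an aromatic carbon. Among the compounds with values here, two measured steps bear on this change. The swap of hydroxy for amino gave a 3.8-fold lower number from compound 2 to compound 3 (0.58 log units; beyond the scatter), and adding hydroxy in place of hydrogen gave a 2.3-fold lower number from compound 1 to compound 3 (0.37 log units; beyond the scatter). Within the data shown here, no measured compound carries methoxy, so compound 2, with hydroxy where compound 3 has amino, is the nearest guide. A modest rise is therefore expected in this assay. The expected change is a 2.3-fold higher number from compound 3 to compound 4 (0.37 log units; beyond the scatter). For compound 4 the estimated value is 14 ug/mL, with an expected range of 6 ug/mL to 35 ug/mL.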

Compound 4, half-maximal inhibitory concentration: 21 ug/mL
Beside the measured number, compound 4's estimate is 1.5-fold (0.18 log units) below it, and the stated range covers the measured number.
By their numbers in this assay, from the lowest: compound 3; then compounds 1, 4 and 2 (each within the scatter of the next).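

In this assay, methoxy in place of amino gave a 3.5-fold higher number from compound 3 to compound 4 (0.54 log units; beyond the scatter), so the lower number of compound 3 does not survive this swap on the aromatic carbon. Methyl in place of hydrogen on the oxygen gave a 1.1-fold lower number from compound 2 to compound 4 (0.04 log units; within the scatter), which places hydroxy and methoxy level here and leaves amino as the only one of the three groups that stands apart. Nothing available explains this difference. On these data alone, it remains open whether a methylamino or acetamido group at this position would keep the number of compound 3.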